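Swapping a methylpyridine on the sulfonyl sulfur

This account rests on a few compounds, and the source may have more. Where it says the series, first, only, none or still open, it means among the compounds named here.

For the measured compounds named here, in an ADME assay on the whole organism (plasma, Rattus norvegicus, strain Sprague-Dawley) for pharmacokinetics, read by LC-MS, using cassette dosing, at a dose of 0.2 mg/kg by the intravenous route (a lower number here means less compound in the circulation, a higher number more compound in the circulation at the dose given), compound 1 (`CNCc1cc(-c2cccnc2F)n(S(=O)(=O)c2cccs2)c1`) gives 27 ng.h/mL as the only number in this small set. For compound 2 (`CNCc1cc(-c2cccnc2F)n(S(=O)(=O)c2ccccn2)c1`) the result reads "not determined" (no result reported) and offers no comparison. Compound 3 (`CNCc1cn(S(=O)(=O)c2ncccc2C)c(-c2cccnc2F)c1F`) also lacks a single number, its entry being "not determined" (no result reported) and so giving no anchor. Compound 4 (`CNCc1cn(S(=O)(=O)c2cccnc2C)c(-c2cccnc2F)c1F`) is still unmeasured. The structural change is 2-methylpyridin-3-yl in place of 3-methylpyridin-2-yl on a sulfonyl sulfur and amounts to 2-methylpyridin-3-yl in place of 3-methylpyridin-2-yl on a sulfonyl sulfur, the same atoms joined differently. In this assay no step beyond the usual scatter is expected from this change. Going by the values given here, the expectation leans on compound 1 at 27 ng.h/mL as the only available number. Compound 4 is estimated at 30 ng.h/mL (expected range 12 ng.h/mL to 75 ng.h/mL).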

Compound 4, area under the concentration-time curve: 32 ng.h/mL
Compound 4: the middle estimate sits 1.1-fold (0.03 log units) below what was measured, and the stated range covers the measured number.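

Compound 3 offers no single number to set against compound 4, and no new step can be read from this pair. On these data alone, whether 2-methylpyridin-3-yl in place of 3-methylpyridin-2-yl on a sulfonyl sulfur shifts the exposure at all remains open. No supporting evidence bears on this result.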